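Swapping an aryl ring on the piperazine of an antiproliferative benzamide

The compounds below may be only part of what the source reports. "The series", "measured", "known", "first", "only" and "open" are said of these compounds alone.

Of the compounds shown here, two have so far been measured in a functional assay on A-375 cells (Homo sapiens) for antiproliferative activity, read by CCK-8 assay, with a stated time of 72 h, tested at 8 uM; a lower number here means a weaker effect, a higher number a stronger effect of the compound at the concentration tested. Compound 1, `Nc1ccccc1NC(=O)c1ccc(CSC(=S)N2CCN(c3ccc(F)cc3)CC2)cc1`, gives 76.3% in this assay. Compound 2, `CCN(Cc1ccncc1)C(=S)SCc1ccc(C(=O)Nc2ccccc2N)cc1`, gives 86.2% in this assay, a number that lies within the usual scatter of the value of compound 1, so the two cannot be told apart on these figures. For the measured compounds named here, no step between two measured compounds that differ in a single place is available here.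

Compound 3, `Nc1ccccc1NC(=O)c1ccc(CSC(=S)N2CCN(c3ncccn3)CC2)cc1`, has not been measured in this assay. Relative to compound 1 its structure changes as follows: pyrimidin-2-yl in place of 4-fluorophenyl on an amine nitrogen in a ring. Going by the values given here, with no comparable step among the measured compounds, there is nothing to suggest that this change should move the read-out beyond the scatter, so a step of roughly no size in either direction is expected. Compound 3 is therefore estimated to give 72% in this assay, with a range from 55% to 88%, which amounts to an expected step of a number 4.3 percentage points lower from compound 1 to compound 3 (within the scatter).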

Compound 3, a percentage reported as inhibition, at one concentration (the size of the read-out at that concentration, not a potency): 67.9%
Beside the measured number, compound 3's estimate is 4.1 percentage points above it, and the stated range covers the measured number.
By their numbers in this assay, from the lowest: compounds 3, 1 and 2 (each within the scatter of the next, the first and the last beyond it).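

In this assay, for the compounds shown here, pyrimidin-2-yl in place of 4-fluorophenyl on an amine nitrogen in a ring gives a number 8.4 percentage points lower from compound 1 to compound 3 (within the scatter) and is the first single-place step available. At this position, the read-out therefore does not separate a six-membered aromatic ring of carbon only from one with 2 hetero atoms, and the 2 hydrogen-bond acceptors that enter bring no step beyond the scatter. No measured evidence bears on this result.

The compounds shown leave open whether a group without an aromatic ring, such as an acetyl group or a short alkyl chain, on that ring nitrogen would give a step beyond the scatter. They also leave open where a pyridin-2-yl ring would fall relative to compound 1 and compound 3.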